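A few compounds are considered here, and "the series" means these few. Any claim that something is new, unique, unknown or untested is made for them only; others in the source may bear on it.

Measured so far:
Compound 1, `Cc1cc(C)cc(C(=O)N(CC(=O)NCc2ccccc2)Cc2ccc(C(=O)Nc3cc(-c4ccccc4)ccc3N)cc2)c1`, gives 8900 nM in a functional assay on CAL-27 cells (Homo sapiens) for cytotoxicity, read by MTT assay, with a stated time of 72 h; on this read-out higher numbers stand for weaker inhibition and lower numbers for stronger inhibition.
Compound 2, `CN(C)c1ccc(C(=O)N(CC(=O)NCc2ccccc2)Cc2ccc(C(=O)Nc3cc(-c4ccccc4)ccc3N)cc2)cc1`, gives 11100 nM in this assay.
Compound 3, `Cc1cc(C)cc(C(=O)N(CCCCCC(=O)Nc2ccccc2N)CC(=O)NCc2ccccc2)c1`, gives 13700 nM in this assay.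

Compound 1 and compound 2 share one core and differ only by 4-(dimethylamino)phenyl in place of 3,5-dimethylphenyl on a carbonyl carbon. That change gave a 1.2-fold higher number from compound 1 to compound 2 (0.10 log units; within the scatter). Compound 3 carries another core; how it differs from the core of compound 1 is not broken down here. Compound 4, `CN(C)c1ccc(C(=O)N(CCCCCC(=O)Nc2ccccc2N)CC(=O)NCc2ccccc2)cc1`, has not yet been measured. It is related to compound 3 by 4-(dimethylamino)phenyl in place of 3,5-dimethylphenyl on a carbonyl carbon, at the same place as before, so this is the same change. Because the earlier example of it gave a 1.2-fold higher number from compound 1 to compound 2 (0.10 log units; within the scatter), the expected step here is a 1.2-fold higher number from compound 3 to compound 4 (0.07 log units; within the scatter), again a small one. Compound 4 is therefore estimated to give about 16000 nM in this assay, most likely between 7000 nM and 40000 nM.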

Compound 4, half-maximal inhibitory concentration: 16000 nM
Compound 4: middle estimate and measured number agree at the digits printed; measured number inside the range.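

In this assay, putting 4-(dimethylamino)phenyl in place of 3,5-dimethylphenyl on the carbonyl carbon gave a 1.2-fold higher number from compound 3 to compound 4 (0.07 log units; within the scatter). Set beside the earlier example, the change behaved alike on both cores: the same change on two cores in this assay, a 1.2-fold higher number (0.10 log units; within the scatter) from compound 1 to compound 2 and a 1.2-fold higher number (0.07 log units; within the scatter) from compound 3 to compound 4, 1.1-fold (0.03 log units) apart, within the scatter of two such steps. Among these compounds, both steps lie within the scatter, so the pair shows only that this swap leaves the number about the same on these two cores; it does not show that the swap has any real effect, or how it would behave on a third core.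

The compounds shown leave open what a clearly different group on this carbonyl carbon would do, such as a phenyl ring carrying a carboxylic acid or a primary amine. They also leave open whether any such group would give a step beyond the scatter.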